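The compounds below may be only part of what the source reports. "The series", "measured", "known", "first", "only" and "open" are said of these compounds alone.

Measured so far in a functional assay on NCI-H1975 cells (Homo sapiens) for antiproliferative activity, read by MTT assay, with a stated time of 72 h; on this read-out lower numbers stand for stronger inhibition and higher numbers for weaker inhibition:
- compound 1 `CN1CCN(c2ccc(Nc3ncc4nc(Nc5ccc(F)cc5)n([C@H]5CCCN(C(=O)CO)C5)c4n3)cc2)CC1`: 750 nM
- compound 2 `CN1CCN(c2ccc(Nc3ncc4nc(Nc5ccc(F)cc5)n([C@H]5CCNC5)c4n3)cc2)CC1`: "not determined" (no result reported)

Compound 2 has no place on the numbers: for compound 2 the entry reads "not determined" (no result reported), so it can be ranked neither above nor below compound 1. Among the measured compounds shown here, its only measured neighbour is compound 1, which carries a different group at the same place on the shared core.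

The next compound to be tested is compound 3 `CN1CCN(c2ccc(Nc3ncc4nc(Nc5ccc(F)cc5)n([C@@H]5CCN(S(=O)(=O)C6CC6)C5)c4n3)cc2)CC1`. The structural change is 1-(cyclopropylsulfonyl)pyrrolidin-3-yl in place of pyrrolidin-3-yl on an aromatic nitrogen of a five-membered aromatic ring with 2 nitrogen.

For the measured compounds named here, no measured step covers this change, and no size of step from the missing number can be stated. The only anchor in this assay is compound 1 at 750 nM, so the working expectation is a result within the scatter of that value, with no direction favoured and a wide margin on both sides. For compound 3 the estimated value is 600 nM, with an expected range of 150 nM to 2500 nM.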

Compound 3, half-maximal inhibitory concentration: > 10000 nM
Compound 3: only a limit was reported; the forecaster's own chance of this, stated with the estimate: 5%; at least 16-fold (1.22 log units) between middle value and limit.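

In this assay compound 3 gives > 10000 nM as a limit of the assay and not as a number. Among the compounds shown here, the group on the aromatic nitrogen clearly matters for this read-out: 1-(cyclopropylsulfonyl)pyrrolidin-3-yl in place of 1-((hydroxymethyl)carbonyl)piperidin-3-yl gives an at least 13-fold higher number from compound 1 to compound 3 (1.12 log units; beyond the scatter) as the first measured size of a change at this place, which the single value available earlier could not supply. How far compound 3 lies past that limit stays unknown, and only the end of the measured range is reached: the limit of > 10000 nM in this assay, at which 1 of the 3 values shown sits.

For the compounds shown here, the step from compound 2 to compound 3 cannot be read, as compound 2 has no result, and the one readable step changes the saturated ring and the group on its nitrogen together, without separating the two. Open, from the compounds shown here alone, is whether a pyrrolidin-3-yl carrying (hydroxymethyl)carbonyl, or a piperidin-3-yl carrying cyclopropylsulfonyl, would read closer to compound 1 or to compound 3, and where a small acetyl group on the same ring nitrogen would fall.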